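This account rests on a few compounds, and the source may have more. Where it says the series, first, only, none or still open, it means among the compounds named here.

Compound 3 `C/C=C/C(=O)N(Cc1ccc(OC)c(Cl)c1)c1cc(OC)c(OC)c(OC)c1` gives 7100 nM in a functional assay on MGC-803 cells (Homo sapiens) for inhibition, read by MTT assay, with a stated time of 48 h (a lower number here means a stronger inhibitor, a higher number a weaker inhibitor), the highest of the three numbers in hand, though its nearest neighbour compound 1 `C/C=C/C(=O)N(Cc1ccc(OC)c(Br)c1)c1cc(OC)c(OC)c(OC)c1`, at 6430 nM, sits within the scatter of it: a 1.1-fold higher number from compound 1 to compound 3 (0.04 log units; within the scatter). Compound 2 `C/C=C/C(=O)N(Cc1ccc(OC)c([N+](=O)[O-])c1)c1cc(OC)c(OC)c(OC)c1` gives 590 nM, and the step of a 12-fold higher number from compound 2 to compound 3 (1.08 log units; beyond the scatter) is the only large one in the set; likewise an 11-fold lower number from compound 1 to compound 2 (1.04 log units; beyond the scatter).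

Compound 4 `C/C=C/C(=O)N(Cc1ccc(OC)cc1)c1cc(OC)c(OC)c(OC)c1` differs from compound 3 by hydrogen in place of chloro on an aromatic carbon. Among the compounds with values here, no measured step removes a substituent at this position outright, so the nearest guide is the halogen swap, a 1.1-fold higher number from compound 1 to compound 3 (0.04 log units; within the scatter), which stayed flat, while both large steps involved the nitro group rather than a halogen. Taking the chloro away is therefore expected to move this assay little, with no step beyond the scatter and if anything a slightly higher number: a 1.1-fold higher number from compound 3 to compound 4 (0.05 log units; within the scatter) is the expected step. Compound 4 is estimated at 8000 nM, in the range 3500 nM to 18000 nM.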

Compound 4, half-maximal inhibitory concentration: 450 nM
Compound 4: the middle estimate sits 18-fold (1.25 log units) above what was measured; the measured number lies below the stated range.
By their numbers in this assay, from the lowest: compounds 4 and 2 (each within the scatter of the next); then compounds 1 and 3 (each within the scatter of the next).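

In this assay the change from 3-chloro-4-methoxyphenyl to 4-methoxyphenyl is large (a 16-fold lower number from compound 3 to compound 4 (1.20 log units; beyond the scatter)), and removing bromo gives a similar result (a 14-fold lower number from compound 1 to compound 4 (1.15 log units; beyond the scatter)), so both halogens sit well above hydrogen at this position. Nitro and hydrogen cannot be told apart here (a 1.3-fold lower number from compound 2 to compound 4 (0.12 log units; within the scatter)), so the earlier large nitro steps now read as a loss with the halogens rather than a gain with nitro. The data at hand offer no explanation for this split, with chloro and bromo on one side and hydrogen and nitro on the other.

A fluoro, hydroxyl or amino group at this position could fall with either pair. On these data alone, whether the gap between halogen and hydrogen holds with other changes to the shared core also remains open.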